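From compound 3 to compound 4 in the agonist read-out

The compounds below may be only part of what the source reports. "The series", "measured", "known", "first", "only" and "open" are said of these compounds alone.

Three compounds of the series carry a measurement. Compound 1 `N[C@@H](COP(=O)(O)OCCCOC(=O)CCc1ccccc1OCc1cccc(Cc2ccccc2)c1)C(=O)O` gives 14.5% in an assay on cells for agonist activity at probable G-protein coupled receptor 34 (Mus musculus), with a stated time of 1 h; on this read-out lower numbers stand for smaller maximal responses and higher numbers for larger maximal responses. Compound 2 `Cc1cccc(Oc2cccc(COc3ccccc3CCC(=O)OCCCOP(=O)(O)OC[C@H](N)C(=O)O)c2)c1` gives 21.3% in this assay, and compound 3 `N[C@@H](COP(=O)(O)OCCCOC(=O)CCc1ccccc1OCc1cccc(Oc2ccc(Br)cc2)c1)C(=O)O` gives 17.7% in this assay. The steps between them are a number 6.8 percentage points higher from compound 1 to compound 2 (within the scatter), a number 3.2 percentage points higher from compound 1 to compound 3 (within the scatter) and a number 3.6 percentage points lower from compound 2 to compound 3 (within the scatter); all three are within the scatter. Compound 3 sits between the other two numbers, nearest to compound 1 and furthest from compound 2, yet neither gap exceeds the scatter, so the three compounds cannot be ordered on these data.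

Compound 4 `CC(C)(C)c1cccc(Oc2cccc(COc3ccccc3CCC(=O)OCCCOP(=O)(O)OC[C@H](N)C(=O)O)c2)c1` differs from compound 3 only in one place: 3-(tert-butyl)phenyl in place of 4-bromophenyl on an oxygen on an aromatic ring. The step that bears most on this is a number 3.6 percentage points lower from compound 2 to compound 3 (within the scatter), where the phenyl on the oxygen on an aromatic ring was varied and the read-out stayed within the scatter; the steps of a number 6.8 percentage points higher from compound 1 to compound 2 (within the scatter) and a number 3.2 percentage points higher from compound 1 to compound 3 (within the scatter) likewise show that exchanges at this position left the maximal response unchanged beyond the scatter. No step beyond the scatter is therefore expected in this assay for compound 4. Compound 4 is estimated at 19%, expected to fall between 9% and 30%. This estimate for compound 4 corresponds to an expected step of a number 1.3 percentage points higher from compound 3 to compound 4 (within the scatter).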

Compound 4, largest response reached (Emax), in percent of the reference or control that the assay uses: 19.9%
The estimate for compound 4 lay 0.9 percentage points below the measured number, within the range that was stated.
By their numbers in this assay, from the lowest: compounds 1, 3, 4 and 2 (each within the scatter of the next).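

In this assay the step of a number 2.2 percentage points higher from compound 3 to compound 4 (within the scatter) shows that 3-(tert-butyl)phenyl, with 10 heavy atoms, can take the place of 4-bromophenyl, with 7, on the oxygen on an aromatic ring without a change beyond the scatter, even though the bromine is lost and the substituent is a different one. The steps of a number 1.4 percentage points lower from compound 2 to compound 4 (within the scatter) and a number 5.4 percentage points higher from compound 1 to compound 4 (within the scatter) extend this to tert-butyl in place of methyl on an aromatic carbon and to 3-(tert-butyl)phenoxy in place of benzyl, so all four compounds remain within the scatter of one another and no order can be drawn among them. Nothing available explains this flat maximal response.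

Still open, from the compounds shown here alone, is whether an amine or a carboxylic acid on this outer phenyl would give a step beyond the scatter in this assay and so show that the position affects the maximal response at all. The compounds shown also leave open whether a longer chain in place of the benzyl or phenoxy link would do so.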